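A benzyl ether swap on an acylurea scaffold

The source may report more compounds than this note shows. Statements on the series, on what has been measured and on what is new or still open speak of the compounds shown alone.

Going by the values given here, compound 2 `Cc1ccc(NC(=O)NC(=O)c2ccc(OCc3cccc(C(F)(F)F)c3)cc2)cc1-c1nc2ccccc2[nH]1` is the only member of this small set with a measured number: in a functional assay on SW-620 cells (Homo sapiens) for inhibition, read by MTT assay, with a stated time of 48 h (a higher number here means a weaker inhibitor, a lower number a stronger inhibitor), compound 2 gives 9640 nM. Compound 1 `Cc1ccc(NC(=S)NC(=O)c2ccc(OCc3cccc(Cl)c3Cl)cc2)cc1-c1nc2ccccc2[nH]1`, which carries a thiocarbonyl where compound 2 has the urea carbonyl and a different benzyl ether, reaches only a limit. In this assay compound 1 gives > 100000 nM, a limit of the assay rather than a number, as recorded by the limit of > 100000 nM in this assay, at which 1 of the 2 values shown sits. Since compound 1 and compound 2 differ in more than one place, their two values do not form a single step and nothing about one exchange can be read from them.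

Compound 3 `Cc1ccc(NC(=O)NC(=O)c2ccc(OCc3ccc(Cl)c(Cl)c3)cc2)cc1-c1nc2ccccc2[nH]1` differs from compound 2 in one place: 3,4-dichlorophenyl in place of 3-(trifluoromethyl)phenyl on a saturated chain carbon bound to an oxygen on an aromatic ring. Among the compounds with values here, no measured pair in the set reports what such an exchange does. With nothing to point to, the step is expected to stay within the usual scatter, with no clear direction. Compound 3 is therefore estimated at 12000 nM in this assay, with a range from 4000 nM to 40000 nM. The expected step of a 1.2-fold higher number from compound 2 to compound 3 (0.10 log units; within the scatter) amounts to no change beyond the scatter.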

Compound 3, half-maximal inhibitory concentration: 6100 nM
Beside the measured number, compound 3's estimate is 2.0-fold (0.29 log units) above it; measured number inside the range.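

In this assay, going by these compounds alone, the exchange of 3-(trifluoromethyl)phenyl for 3,4-dichlorophenyl gives the first step that can be read at this position: a 1.6-fold lower number from compound 2 to compound 3 (0.20 log units; within the scatter), which stays within the usual scatter. The earlier compounds shown here offered no pair differing in one place, whereas this pair shows that, on the saturated chain carbon bound to an oxygen on an aromatic ring, these two substituted phenyl groups cannot be told apart by this read-out. No measurement shown here offers a reason for this result.

The compounds shown leave open whether this position would give the same picture with a phenyl ring carrying an amine or a carboxylic acid, or with a longer chain in place of the single saturated carbon. The thiocarbonyl of compound 1 also has no partner that differs from it in one place, so its share in that compound's limit of > 100000 nM, which is a limit of the assay and not a number, cannot be read.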